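A few compounds are considered here, and "the series" means these few. Any claim that something is new, unique, unknown or untested is made for them only; others in the source may bear on it.

Of the compounds shown here, three have so far been measured in a functional assay (aorta) with Oryctolagus cuniculus as the target; a higher number here means weaker binding, a lower number tighter binding. Compound 1 `COc1cc(C(C)=O)ccc1OCCCN1CCC(C(c2ccccc2)c2ccccc2)CC1` gives 6.31 nM in this assay. Compound 2 `COc1cc(C(C)=O)ccc1OCCCN1CCC(C(O)(c2ccc(F)c(F)c2)c2ccc(F)c(F)c2)CC1` gives 2.51 nM. Compound 3 `CCc1ccc(OCCCN2CCC(C(c3ccc(F)cc3)c3ccc(F)cc3)CC2)c(OC)c1` gives 2.51 nM, level with compound 2 at the digits shown and, together with it, the lowest of the three numbers; compound 1 sits higher by a gap that is beyond the scatter. Compound 4 `CN(CCCN1CCC(C(c2ccc(F)cc2)c2ccc(F)cc2)CC1)c1ccccc1` awaits measurement. It differs from compound 3 thus: methyl(phenyl)amino in place of 4-ethyl-2-methoxyphenoxy on a saturated chain carbon, three bonds along the chain from an amine nitrogen in a ring. For the measured compounds named here, no measured pair shows this change, so nothing here tells its effect. A modest upward step, a 2.5-fold higher number from compound 3 to compound 4 (0.40 log units; beyond the scatter), is expected, because compound 3 at 2.51 nM already stands at the low end of the measured range. Compound 4 is estimated at 6.3 nM, between 2 nM and 20 nM.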

Compound 4, dissociation constant: 2 nM
For compound 4 the middle estimate is 3.2-fold (0.50 log units) above the measured one; the measured number falls inside the stated range.
By their numbers in this assay, from the lowest: compounds 4, 2 and 3 (each within the scatter of the next); then compound 1.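

In this assay, methyl(phenyl)amino in place of 4-ethyl-2-methoxyphenoxy gives a 1.3-fold lower number from compound 3 to compound 4 (0.10 log units; within the scatter), so this chain position tolerates the exchange without a shift beyond the scatter. The entering group has fewer heavy atoms and fewer hydrogen-bond acceptors, and the number still holds within the scatter. Nothing measured here explains this result. The compounds shown leave open how a plain phenoxy group or an unsubstituted anilino group, with hydrogen in place of the nitrogen's methyl, would read in this assay on this chain. They also leave open whether a longer chain would keep this level.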